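The source may report more compounds than this note shows. Statements on the series, on what has been measured and on what is new or still open speak of the compounds shown alone.

Compound 1 `Cc1c(OC[C@@H](C)COc2ccc(Cl)c(C(=O)O)c2)ccc(C(=O)CC(C)(C)C)c1O`: 2200 nM
Compound 2 `Cc1c(OC[C@@H](C)COc2ccc(C(=O)O)cc2Cl)ccc(C(=O)CC(C)(C)C)c1O`: 1650 nM
Compound 3 `Cc1c(OC[C@@H](C)COc2ccc(C(=O)O)c(F)c2)ccc(C(=O)CC(C)(C)C)c1O`: 1090 nM

In an assay for positive allosteric modulation of metabotropic glutamate receptor 3 (Rattus norvegicus) (on this read-out higher numbers stand for an effect only at larger amounts of compound and lower numbers for an effect already at smaller amounts), the three measured compounds differ only in the aryl group on an oxygen on a saturated carbon. Compound 3 gives the lowest of the three numbers, yet the steps of a 2.0-fold lower number from compound 1 to compound 3 (0.30 log units; within the scatter) and a 1.5-fold lower number from compound 2 to compound 3 (0.18 log units; within the scatter) both lie within the scatter, as does a 1.3-fold lower number from compound 1 to compound 2 (0.12 log units; within the scatter), so the three cannot be told apart on these data.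

Compound 4 `Cc1c(OC[C@@H](C)COc2ccc3c(c2)C(=O)NC3)ccc(C(=O)CC(C)(C)C)c1O` continues the same series: a group of 10 heavy atoms (8 carbon, 1 nitrogen, 1 oxygen; one five-membered non-aromatic ring with 1 hetero atom, one six-membered aromatic ring of carbon only) in place of a group of 10 heavy atoms (7 carbon, 2 oxygen, 1 fluorine; one six-membered aromatic ring of carbon only), on an oxygen on a saturated carbon. The three measured steps bear on it only in part. They show that moving a carboxy and a halogen around the aryl ring left this assay essentially unchanged, every step falling within the scatter. None of them, however, removed the carboxy group or brought in a fused five-membered ring with a nitrogen, so the change to compound 4 reaches beyond anything tested.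

Given that the measured aryl swaps produced no step beyond the scatter, compound 4 is expected to land near compound 3, with wide uncertainty. The estimate for compound 4 is 1500 nM, within a range of 400 nM to 6000 nM. This expectation corresponds to a 1.4-fold higher number from compound 3 to compound 4 (0.14 log units; within the scatter).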

Compound 4, half-maximal effective concentration: "not active" (no number reported)
The entry for compound 4 holds no number; no gap can be computed for the estimate.
By their numbers in this assay, from the lowest: compounds 3, 2 and 1 (each within the scatter of the next).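

In this assay, going by these compounds alone, compound 4 is recorded as not active, without a number, so no step from compound 3 to it can be read. Nothing measured here speaks to why. The compounds shown leave open whether any aryl group without the carboxy, or with this fused five-membered ring, gives a measurable number.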